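From compound 2 to compound 3: an expected toxicity reading

The source may report more compounds than this note shows. Statements on the series, on what has been measured and on what is new or still open speak of the compounds shown alone.

In a toxicity assay on L132 cells (Homo sapiens) for inhibition, read by MTT assay, with a stated time of 48 h (on this read-out higher numbers stand for weaker inhibition and lower numbers for stronger inhibition), compound 1 `CN1CCCN(CCNc2nccc(-c3c(-c4cccc(O)c4)nc4sccn34)n2)S1(=O)=O` gives 93600 nM and compound 2 `O=S(=O)(NCCCNc1nccc(-c2c(-c3cccc(O)c3)nc3sccn23)n1)c1cccc(F)c1` gives 56300 nM as its reading. These two numbers lie within the scatter of each other, so compound 2 stands level with compound 1 and holds no separate rank.

Compound 3 `O=S(=O)(NCCNc1nccc(-c2c(-c3cccc(O)c3)nc3sccn23)n1)c1ccc(F)cc1` is not yet measured. Against compound 2 the change is ((4-fluorophenyl)sulfonyl)amino in place of (((3-fluorophenyl)sulfonyl)amino)methyl on a saturated chain carbon, two bonds along the chain from a nitrogen on an aromatic ring on the same saturated chain carbon, so ((4-fluorophenyl)sulfonyl)amino stands in place of (((3-fluorophenyl)sulfonyl)amino)methyl. Among the measured compounds shown here, only one measured step bears on this place, and it involves a different exchange. Because a 1.7-fold lower number from compound 1 to compound 2 (0.22 log units; within the scatter) stayed within the scatter, no step beyond the scatter is expected here. The step expected in this assay is a 1.1-fold higher number from compound 2 to compound 3 (0.03 log units; within the scatter) on this slender evidence. For compound 3 the estimated value is 60000 nM with an expected range from 28000 nM to 125000 nM in this reading.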

Compound 3, half-maximal inhibitory concentration: 52400 nM
Compound 3: middle estimate off by 1.1-fold (0.06 log units), on the high side; the range from low to high includes it.
By their numbers in this assay, from the lowest: compounds 3, 2 and 1 (each within the scatter of the next).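

In this assay, the exchange on a saturated chain carbon, two bonds along the chain from a nitrogen on an aromatic ring, gives a 1.1-fold lower number from compound 2 to compound 3 (0.03 log units; within the scatter), so ((4-fluorophenyl)sulfonyl)amino and (((3-fluorophenyl)sulfonyl)amino)methyl cannot be told apart on this read-out. Against the non-aromatic ring group of compound 1, the group of compound 3 gives a 1.8-fold lower number from compound 1 to compound 3 (0.25 log units; within the scatter), so neither fluorophenyl group separates from that group, and all three compounds remain level. No accompanying data explain this levelness.

The step from compound 2 to compound 3 alters the fluorophenyl group and removes the methyl link together, leaving the contribution of each open. Also open, going by these compounds, is whether a carboxylic acid or a primary amine at this place would give a reading beyond the scatter.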